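Cytotoxicity notes: cyclopentyl to methyl on the amine

This account rests on a few compounds, and the source may have more. Where it says the series, first, only, none or still open, it means among the compounds named here.

Measured so far in an ADME assay on CCRF-HSB-2 cells (Homo sapiens) for cytotoxicity, with a stated time of 7 days; on this read-out lower numbers stand for higher toxicity in this test and higher numbers for lower toxicity in this test:
- compound 1 `CC(C)CNc1nc(N)nc2c1ncn2/C=C1/CC1(CO)CO` gives > 20000 nM, a limit of the assay.
- compound 2 `Nc1nc(OCC(F)(F)F)c2ncn(/C=C3/CC3(CO)CO)c2n1` gives > 20000 nM, a limit of the assay.
- compound 3 `Nc1nc(NC2CCCC2)c2ncn(/C=C3/CC3(CO)CO)c2n1` gives > 20000 nM, a limit of the assay.

Compound 3 stands at the limit of > 20000 nM in this assay, at which 3 of the 3 values shown sit, so its position is known only as a limit, not as a number. The steps that touch it, a step that the two limits leave unreadable from compound 1 to compound 3 and a step that the two limits leave unreadable from compound 2 to compound 3, are both unreadable in size, and a step that the two limits leave unreadable from compound 1 to compound 2 is the same. Among the compounds with values here, no measured step gives a readable size, so none sets a direction.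

Compound 4 `CNc1nc(N)nc2c1ncn2/C=C1/CC1(CO)CO` differs from compound 3 by methyl in place of cyclopentyl on a nitrogen on an aromatic ring. The comparable exchange of the group on the nitrogen, from isobutyl to cyclopentyl, left both compounds at the limit. Compound 4 is therefore expected to sit at the limit as well, with no readable step that the limit leaves unreadable from compound 3 to compound 4. The estimate for compound 4 in this assay is 30000 nM, in the range 15000 nM to 80000 nM, with the value most probably reported again only as a limit.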

Compound 4, half-maximal cytotoxic concentration: > 20000 nM
Compound 4: no number, only a limit; the forecaster's own chance of this, stated with the estimate: 85%; the middle value lies beyond the limit too.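

Within the data shown here, compound 4 is also reported only as a limit, and no step among compounds 1, 2, 3 and 4 can be read in size: the limit of > 20000 nM in this assay, at which 4 of the 4 values shown sit. The compounds shown leave open how far each lies beyond that limit, and whether any group on the shared core gives a measurable cytotoxic concentration.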